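This account rests on a few compounds, and the source may have more. Where it says the series, first, only, none or still open, it means among the compounds named here.

Compound 1 `C[C@H]1CC[C@@H]2[C@@H](OC(=O)[C@]23CC(c2c(Cl)cccc2Cl)=NO3)[C@]2(C)C(=O)C=C[C@@]12O` is tested in a functional assay on DU-145 cells (Homo sapiens) for cytotoxicity, read by sulforhodamine B assay, with a stated time of 48 h (a higher number here means a weaker inhibitor, a lower number a stronger inhibitor), where compound 1 gives 38000 nM. Among the three measured compounds this places compound 1 second highest. Its nearest neighbour is compound 2 `C[C@H]1CC[C@@H]2[C@@H](OC(=O)[C@]23CC(c2ccc(Cl)cc2)=NO3)[C@]2(C)C(=O)C=C[C@@]12O`, which in this assay gives 43000 nM, a step of a 1.1-fold higher number from compound 1 to compound 2 (0.05 log units; within the scatter). Furthest from it is compound 3 `C[C@H]1CC[C@@H]2[C@@H](OC(=O)[C@]23CC(c2ccccc2Cl)=NO3)[C@]2(C)C(=O)C=C[C@@]12O`, which in this assay gives 19000 nM, a step of a 2.0-fold lower number from compound 1 to compound 3 (0.30 log units; within the scatter). Between the two chlorophenyl isomers the step is a 2.3-fold lower number from compound 2 to compound 3 (0.35 log units; beyond the scatter).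

Compound 4 `C[C@H]1CC[C@@H]2[C@@H](OC(=O)[C@]23CC(c2ccc(C#N)cc2)=NO3)[C@]2(C)C(=O)C=C[C@@]12O` differs from compound 1 by 4-cyanophenyl in place of 2,6-dichlorophenyl on a carbon with a double bond to nitrogen. Among the measured compounds shown here, the step that bears most directly on this change is the one from compound 1 to compound 2, where a 4-chlorophenyl replaced the same 2,6-dichlorophenyl and the number stayed within the scatter. No measured step shows a 4-cyanophenyl or any nitrile, so the effect of exchanging chloro for cyano in the same ring position rests on no shown data. On balance a step within the scatter is expected in this assay, with no firm direction.

Compound 4 is therefore estimated at 40000 nM in this assay, with a range from 18000 nM to 90000 nM. This estimate corresponds to an expected step of a 1.1-fold higher number from compound 1 to compound 4 (0.02 log units; within the scatter).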

Compound 4, half-maximal inhibitory concentration: 26000 nM
The estimate for compound 4 lay 1.5-fold (0.19 log units) above the measured number, and the stated range covers the measured number.
By their numbers in this assay, from the lowest: compounds 3, 4, 1 and 2 (each within the scatter of the next, the first and the last beyond it).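

In this assay the carbon with a double bond to nitrogen now carries a 4-cyanophenyl, the only group shown here with a triple bond and a hydrogen-bond acceptor, and the number stays with those of the chlorinated rings: there is a 1.5-fold lower number from compound 1 to compound 4 (0.16 log units; within the scatter) against the 2,6-dichlorophenyl and a 1.4-fold higher number from compound 3 to compound 4 (0.14 log units; within the scatter) against the 2-chlorophenyl. The direct exchange of chloro for cyano on an aromatic carbon gives a 1.7-fold lower number from compound 2 to compound 4 (0.22 log units; within the scatter) and so, unlike the step between the two chlorophenyl isomers, does not pass beyond the scatter. Nothing available accounts for how closely these aryl groups agree in this cell assay.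

On these data alone, all four compounds carry a substituted phenyl ring at this position, so it remains open whether a phenyl ring bearing an amine or a carboxylic acid, a cyclohexyl ring or a longer alkyl chain would give a clearly different number. As far as these compounds go, it also remains open whether a change elsewhere on the shared core would move the number further than any change seen at this position.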